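The compounds below may be only part of what the source reports. "The series", "measured", "known", "first", "only" and "open" are said of these compounds alone.

Compound 1 `Cn1cc(SCC(=O)Nc2ccccc2Cl)c2ccccc21`, compound 2 `COc1cccc2c(SCC(=O)Nc3ccc(Cl)c(Cl)c3)c[nH]c12` and compound 3 `Cn1cc(SCC(=O)Nc2ccc(Cl)cc2Cl)c2ccccc21` have been measured in an ADME assay on HEK-293T cells (Homo sapiens) for cytotoxicity, read by CCK-8 assay, with a stated time of 48 h; a higher number here means that more compound is tolerated, a lower number that less compound is tolerated. In this assay compound 1 reaches only the limit > 100000 nM. Compound 2 likewise reaches only the limit > 100000 nM. Compound 3 also reaches only the limit > 100000 nM. Compound 1 therefore stands at a limit, and the two further values shown are limits as well; all three sit at the limit of > 100000 nM in this assay, at which 3 of the 3 values shown sit.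

Compound 4 `Cn1cc(SCC(=O)Nc2cccc(Cl)c2)c2ccccc21` is not yet measured. It differs from compound 1 by 3-chlorophenyl in place of 2-chlorophenyl on an amide-type nitrogen. Within the data shown here, the one step that bears on it, a step that the two limits leave unreadable from compound 1 to compound 3, has limits at both ends, so its size is not readable. No step beyond the scatter is expected. Compound 4 is expected to give 100000 nM, between 30000 nM and 300000 nM. The expected step is a number no higher from compound 1 to compound 4 (the limit leaves the size open).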

Compound 4, half-maximal cytotoxic concentration: > 100000 nM
Compound 4 ended at the assay's limit; the forecaster's own chance of this, stated with the estimate: 85%; the middle value lies on the limit itself.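

In this assay no step can be read between compound 1 and compound 4, because both stand at a limit: the limit of > 100000 nM in this assay, at which 4 of the 4 values shown sit. The compounds shown leave open whether 3-chlorophenyl and 2-chlorophenyl differ at all in how much compound is tolerated.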